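Swapping chloro for trifluoromethyl on the fused core

The compounds below may be only part of what the source reports. "The series", "measured", "known", "first", "only" and "open" are said of these compounds alone.

Of the compounds shown here, three sharing one core have been measured in a functional assay on HEK293 cells for antagonist activity at prostaglandin E2 receptor EP4 subtype (Homo sapiens), read by scintillation proximity assay and cAMP accumulation; on this read-out lower numbers stand for stronger inhibition and higher numbers for weaker inhibition. Compound 1 `C[C@H](NC(=O)c1cccc2c1N(Cc1ccc(Cl)cc1Br)CC2)c1ccc(C(=O)O)cc1` gives 8.3 nM, compound 2 `Cc1ccc(CN2CCc3cccc(C(=O)N[C@@H](C)c4ccc(C(=O)O)cc4)c32)cc1` gives 5.8 nM, and compound 3 `C[C@H](NC(=O)c1cc(Cl)cc2c1N(Cc1ccc(C(F)(F)F)cc1)CC2)c1ccc(C(=O)O)cc1` gives 2.2 nM, the lowest number of the three, with both gaps beyond the scatter. For the measured compounds named here, the one single-point step measured, a 1.4-fold lower number from compound 1 to compound 2 (0.16 log units; within the scatter), concerns the benzyl aryl group and not the core. Compound 4 `C[C@H](NC(=O)c1cc(C(F)(F)F)cc2c1N(Cc1ccc(C(F)(F)F)cc1)CC2)c1ccc(C(=O)O)cc1` differs from compound 3 by trifluoromethyl in place of chloro on an aromatic carbon. Going by the values given here, no measured step touches this position, so nothing here bears directly on the change, and the expected step from compound 3 to compound 4 is a 1.1-fold higher number from compound 3 to compound 4 (0.06 log units; within the scatter), none beyond the scatter. Compound 4 is therefore estimated at 2.5 nM, between 0.9 nM and 7 nM in this assay.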

Compound 4, half-maximal inhibitory concentration: 3 nM
Compound 4: the middle estimate sits 1.2-fold (0.08 log units) below what was measured; the measured number falls inside the stated range.
By their numbers in this assay, from the lowest: compounds 3, 4, 2 and 1 (each within the scatter of the next, the first and the last beyond it).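

In this assay, trifluoromethyl in place of chloro on this aromatic carbon gives a 1.4-fold higher number from compound 3 to compound 4 (0.13 log units; within the scatter) and so leaves compound 3 and compound 4 within the scatter of each other, even with four heavy atoms entering where one leaves. For the compounds shown here, this is the first measured step at this position of the shared core, as the earlier step concerned only the benzyl aryl group. No measurement available here accounts for this result. As far as these compounds go, whether an amine, a methoxy group or a nitrile on this carbon would also stay within the scatter of compound 3 remains open.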